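Methoxy for methyl on a coumarin-triazole antiproliferative series

The source may report more compounds than this note shows. Statements on the series, on what has been measured and on what is new or still open speak of the compounds shown alone.

Compound 1 `Cc1ccc(-c2cn(-c3cc4ccc(O)c(C)c4oc3=O)nn2)cc1` gives 23200 nM in a functional assay on MCF7 cells (Homo sapiens) for antiproliferative activity; a higher number here means a weaker inhibitor, a lower number a stronger inhibitor.
Compound 2 `CC(=O)Oc1ccc2cc(-n3cc(-c4ccc(C)cc4)nn3)c(=O)oc2c1C` gives > 100000 nM in this assay, which is a limit of the assay and not a number.
Compound 3 `CO[C@@H]1[C@@H](O)[C@@H](O)[C@H](Oc2ccc3c(c2C)OC(=O)C(n2cc(-c4ccc(C)cc4)nn2)C3)OC1(C)C` gives > 100000 nM in this assay, again a limit of the assay rather than a number.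

Compound 2 thus stands at the limit of > 100000 nM in this assay, at which 2 of the 3 values shown sit. For the measured compounds named here, the only measured step, an at least 4.3-fold higher number from compound 1 to compound 2 (0.63 log units; beyond the scatter), concerns the oxygen substituent and does not touch the phenyl ring. Compound 4 `COc1ccc(-c2cn(-c3cc4ccc(OC(C)=O)c(C)c4oc3=O)nn2)cc1` differs from compound 2 by methoxy in place of methyl on an aromatic carbon. Going by the values given here, no measured step bears on this position, so no shift beyond the scatter is expected, and compound 4 is expected to stay at the limit, an estimated 100000 nM (range 30000 nM to 300000 nM), a step of a number no higher from compound 2 to compound 4 (the limit leaves the size open).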

Compound 4, half-maximal inhibitory concentration: > 100000 nM
Compound 4 gave a limit, no number (the forecaster's own chance of this, stated with the estimate: 70%); the middle value lies on the limit itself.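

Compound 2 and compound 4 both sit at a limit of the assay and not at a number, so no step can be read between them: the limit of > 100000 nM in this assay, at which 3 of the 4 values shown sit.

The compounds shown leave open whether 4-methoxyphenyl and 4-methylphenyl differ at all in this assay.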